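Nitro in place of bromo on the amide aryl group

The compounds below may be only part of what the source reports. "The series", "measured", "known", "first", "only" and "open" are said of these compounds alone.

In a functional assay on KB cells (Homo sapiens) for antiproliferative activity, read by MTT assay, with a stated time of 72 h (a higher number here means a weaker inhibitor, a lower number a stronger inhibitor), compound 3 `CN(C(=O)c1ccc(Br)cc1)c1ccc2[nH]c(-c3n[nH]c4ccccc34)cc2n1` gives 1780 nM, the lowest of the three numbers shown. Compound 1 `CN(C(=O)CCc1ccccc1)c1ccc2[nH]c(-c3n[nH]c4ccccc34)cc2n1` gives 7380 nM and compound 2 `CN(C(=O)c1ccc(F)cc1)c1ccc2[nH]c(-c3n[nH]c4ccccc34)cc2n1` gives 7220 nM. The step of a 1.0-fold lower number from compound 1 to compound 2 (0.01 log units; within the scatter) changes nothing, whereas a 4.1-fold lower number from compound 1 to compound 3 (0.62 log units; beyond the scatter) and a 4.1-fold lower number from compound 2 to compound 3 (0.61 log units; beyond the scatter) both move beyond the scatter. Compound 4 `CN(C(=O)c1ccc([N+](=O)[O-])cc1)c1ccc2[nH]c(-c3n[nH]c4ccccc34)cc2n1` carries nitro in place of bromo on an aromatic carbon. Among the measured compounds shown here, no measured step exchanges a halogen for a nitro group; the one step at this aromatic carbon, a 4.1-fold lower number from compound 2 to compound 3 (0.61 log units; beyond the scatter), shows only that the group here can shift the number beyond the scatter, not which way a nitro group would shift it. For compound 4 the expected step is therefore a 2.0-fold higher number from compound 3 to compound 4 (0.29 log units; within the scatter), with a wide range. The estimate for compound 4 is 3500 nM, between 1200 nM and 9000 nM.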

Compound 4, half-maximal inhibitory concentration: 20200 nM
Beside the measured number, compound 4's estimate is 5.8-fold (0.76 log units) below it; measured number outside the range, above it.
By their numbers in this assay, from the lowest: compound 3; then compounds 2 and 1 (each within the scatter of the next); then compound 4.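

In this assay, this aromatic carbon now shows movement in both directions: nitro in place of bromo (an 11-fold higher number from compound 3 to compound 4 (1.05 log units; beyond the scatter)) is a larger step than fluoro to bromo. Nitro also separates from fluoro (a 2.8-fold higher number from compound 2 to compound 4 (0.45 log units; beyond the scatter)), and the 4-nitrophenyl amide separates from the phenethyl amide (a 2.7-fold higher number from compound 1 to compound 4 (0.44 log units; beyond the scatter)), leaving compound 4 with the highest number of the four. Nothing available bears on the cause of these steps.

Open, from the compounds shown here alone, is where chloro, iodo, an amine or a carboxylic acid on this carbon would fall. Also open, going by these compounds, is whether bromo keeps its lead over a methoxy group.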